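The source may report more compounds than this note shows. Statements on the series, on what has been measured and on what is new or still open speak of the compounds shown alone.

Measured compounds, antiproliferative readings:

- compound 1 `N=C(N)NS(=O)(=O)c1ccc(N/C(S)=N\c2ccnc3cc(C(F)(F)F)ccc23)cc1` — 23900 nM
- compound 2 `Cc1cc(NS(=O)(=O)c2ccc(N/C(S)=N\c3ccnc4cc(C(F)(F)F)ccc34)cc2)on1` — "not active" (no number reported)
- compound 3 `O=S(=O)(Nc1ccccn1)c1ccc(N/C(S)=N\c2ccnc3cc(C(F)(F)F)ccc23)cc1` — 87500 nM

Going by the values given here, in a functional assay on LoVo cells (Homo sapiens) for antiproliferative activity, read by sulforhodamine B assay, with a stated time of 48 h (a lower number here means a stronger inhibitor, a higher number a weaker inhibitor), compound 3 gives 87500 nM, the highest of the two numbers; its nearest neighbour is compound 1, and the step of a 3.7-fold higher number from compound 1 to compound 3 (0.56 log units; beyond the scatter) is the only single-point change with a number on both sides. Compound 2, with its own ring on the sulfonamide nitrogen, gave no number at all.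

Compound 4 `COc1ncnc(NS(=O)(=O)c2ccc(N/C(S)=N\c3ccnc4cc(C(F)(F)F)ccc34)cc2)c1OC` carries the change (5,6-dimethoxypyrimidin-4-yl in place of pyridin-2-yl on a sulfonamide nitrogen). Among the compounds with values here, no measured step shows this exact exchange. What the series does show is that the group on the sulfonamide nitrogen is where the numbers move, and that the two ring-bearing members, compound 2 and compound 3, sit at the weak end, with compound 3 already weaker than compound 1 by a 3.7-fold higher number from compound 1 to compound 3 (0.56 log units; beyond the scatter). A further ring bearing more acceptors is therefore expected to land near compound 3 or somewhat weaker, with a real chance of no number being returned. Compound 4 is estimated at 120000 nM (range 40000 nM to 350000 nM), a step of a 1.4-fold higher number from compound 3 to compound 4 (0.14 log units; within the scatter) that is expected to lie around the edge of the scatter.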

Compound 4, half-maximal inhibitory concentration: 28400 nM
Estimate against measurement, compound 4: 4.2-fold (0.63 log units) above; measured number below the stated range.
By their numbers in this assay, from the lowest: compounds 1 and 4 (each within the scatter of the next); then compound 3.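

In this assay, the group on the sulfonamide nitrogen can carry a ring without the number moving to the weak end: 5,6-dimethoxypyrimidin-4-yl in place of pyridin-2-yl gives a 3.1-fold lower number from compound 3 to compound 4 (0.49 log units; beyond the scatter). Compound 4 also stands level with the ringless group of compound 1, at a 1.2-fold higher number from compound 1 to compound 4 (0.07 log units; within the scatter), so a ring at this position does not by itself separate the two, and the larger group costs nothing measurable here. No evidence bears on what lies behind this shift.

The compounds shown leave open whether the shift follows the second ring nitrogen or the two methoxy groups, which an unsubstituted pyrimidin-4-yl would help separate. They also leave open how a plain phenyl or an unsubstituted sulfonamide amine would read.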